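Removing a Methyl Group From Compound 1

The source may hold more compounds than are shown below. What is called first, only, known or untested is meant among the compounds shown, and "the series" means these compounds.

Compound 1 `Cc1cc(C#Cc2ccc(CCC(=O)O)cc2)nc(Cl)n1` was tested in an in vitro functional assay on 1321-N1 cells for agonist activity at Free fatty acid receptor 1 (Homo sapiens), read by fluorescence, spectrophotometry and calcium flux (a higher number here means that more compound is needed for the effect, a lower number that less compound is needed), where compound 1 gives 2750 nM. That is the highest number among the three compounds measured. Compound 2 `O=C(O)CCc1ccc(C#Cc2ccnc(Cl)c2)cc1` gives 295 nM, and compound 3 `Cc1cc(Oc2ncc(C(F)(F)F)cc2Cl)ccc1CC1SC(=O)NC1=O` gives 87.1 nM; both lie beyond the scatter below compound 1. Compound 4 `O=C(O)CCc1ccc(C#Cc2ccnc(Cl)n2)cc1` has not yet been measured. It differs from compound 1 in one place: hydrogen in place of methyl on an aromatic carbon. For the measured compounds named here, no measured pair shows this exact change, so the size of the step must be guessed. A modest step toward a lower number is expected, giving an estimated change of a 2.3-fold lower number from compound 1 to compound 4 (0.36 log units; beyond the scatter). For compound 4 the estimated value is 1200 nM, in a range from 400 nM to 3500 nM.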

Compound 4, half-maximal effective concentration: 9120 nM
Beside the measured number, compound 4's estimate is 7.6-fold (0.88 log units) below it; the measured number lies above the stated range.
By their numbers in this assay, from the lowest: compound 3; then compound 2; then compound 1; then compound 4.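

On the core of compound 1, the methyl group on this aromatic carbon, next to the ring nitrogen, is worth keeping: in this assay, replacing it with hydrogen gives a 3.3-fold higher number from compound 1 to compound 4 (0.52 log units; beyond the scatter). Less compound is needed with the methyl present, so removing this single carbon does not help at this position. Nothing measured here explains the step.

On these data alone, whether an ethyl or a methoxy group at this position would lower the number below that of compound 1 remains open. As far as these compounds go, whether the same step would appear on a different core also remains open.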